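Fluoro Substitution on the Core of Compound 2

The compounds below may be only part of what the source reports. "The series", "measured", "known", "first", "only" and "open" are said of these compounds alone.

Compound 2 `C#CCn1cc(C(=O)NC(CC(=O)NC2CCCC2)c2ccccc2)c(=O)c2ccc(Cl)nc21`, in a functional assay on KB cells (Homo sapiens) for cytotoxicity, read by MTT assay, with a stated time of 72 h (a higher number here means a weaker inhibitor, a lower number a stronger inhibitor), gives only a limit of the assay, > 10000 nM. Compound 1 `C#CCn1cc(C(=O)NC(CC(=O)Nc2ccccc2)c2ccccc2)c(=O)c2cc(F)c(Cl)nc21` likewise gives only a limit in this assay, > 10000 nM. Both shown values thus sit at the limit of > 10000 nM in this assay, at which 2 of the 2 values shown sit, so compound 2 stands at the limit and no ordering between the two measured compounds can be drawn. Compound 3 `C#CCn1cc(C(=O)NC(CC(=O)NC2CCCC2)c2ccccc2)c(=O)c2cc(F)c(Cl)nc21` differs from compound 2 by fluoro in place of hydrogen on an aromatic carbon. Within the data shown here, no measured step isolates this change; no shift beyond the scatter is expected in this assay, with a step that the limit leaves unreadable from compound 2 to compound 3 the expected step. Compound 3 is estimated at 15000 nM, range 5000 nM to 50000 nM, most likely again reported only as a limit.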

Compound 3, half-maximal inhibitory concentration: 4900 nM
Estimate against measurement, compound 3: 3.1-fold (0.49 log units) above, outside the stated range (below it).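

In this assay, compound 3 is the only compound shown that gives a number rather than a limit, and it combines fluoro on the core with cyclopentyl on the amide-type nitrogen. Fluoro in place of hydrogen gives an at least 2.0-fold lower number from compound 2 to compound 3 (0.30 log units; that floor lies within the scatter), and cyclopentyl in place of phenyl gives an at least 2.0-fold lower number from compound 1 to compound 3 (0.30 log units; that floor lies within the scatter). The true size of neither step can be read, because compound 1 and compound 2 stand at a limit: the limit of > 10000 nM in this assay, at which 2 of the 3 values shown sit.

Open, on these data alone, is how an amine in place of the chloro group would read on this core. Also open, as far as these compounds go, is how a longer chain would compare with cyclopentyl on the amide-type nitrogen.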